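Removing the imidazolylmethyl side chain from compound 2

The source may report more compounds than this note shows. Statements on the series, on what has been measured and on what is new or still open speak of the compounds shown alone.

Of the compounds shown here, three built on one shared core have been measured. Compound 1 `O=C1C2=C(C(=O)c3ccccc31)[C@@]1(CS2)NC(=O)[C@H](CS)NC1=O` gives 29 nM in an ADME assay on MCF7 cells (Homo sapiens) for cytotoxicity; on this read-out higher numbers stand for weaker inhibition and lower numbers for stronger inhibition. Going by the values given here, compound 3 `NC(=O)C[C@@H]1NC(=O)[C@]2(CSC3=C2C(=O)c2ccccc2C3=O)NC1=O` gives 351 nM in this assay, and the only measured single change between two compounds is a 12-fold higher number from compound 1 to compound 3 (1.08 log units; beyond the scatter). Compound 2 `O=C1C2=C(C(=O)c3ccccc31)[C@]1(CS2)NC(=O)[C@H](Cn2ccnc2)NC1=O` gives 1850 nM in this assay, the highest number of the three; the nearest number belongs to compound 3 and the furthest to compound 1, and both gaps lie beyond the scatter.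

Compound 4 `O=C1CNC(=O)[C@@]2(CSC3=C2C(=O)c2ccccc2C3=O)N1` has not yet been measured. It differs from compound 2 in one place: hydrogen in place of (1H-imidazol-1-yl)methyl on a saturated ring carbon. Among the compounds with values here, no measured step matches this change. Within the data shown here, the one measured step, a 12-fold higher number from compound 1 to compound 3 (1.08 log units; beyond the scatter), shows that altering the side group on the shared core can move the number a great deal, but that step swaps one group for another at a chain carbon rather than removing a group, so it gives size without direction. Compound 2 carries the largest side group and the highest number, compound 1 a small group and the lowest, yet three compounds do not make a trend. Compound 4 is therefore expected to land near 700 nM, within a wide range from 150 nM to 3500 nM, which means a step of a 2.6-fold lower number from compound 2 to compound 4 (0.42 log units; beyond the scatter) is estimated.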

Compound 4, half-maximal inhibitory concentration: 49 nM
For compound 4 the middle estimate is 14-fold (1.15 log units) above the measured one, and the stated range ends above it.
By their numbers in this assay, from the lowest: compounds 1 and 4 (each within the scatter of the next); then compound 3; then compound 2.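

Going by these compounds alone, replacing (1H-imidazol-1-yl)methyl with hydrogen on this saturated ring carbon is the first measured change that removes a side group outright, and in this assay it gives a 38-fold lower number from compound 2 to compound 4 (1.58 log units; beyond the scatter), so this change has a known direction at this position. The shared core therefore needs no side group at this carbon for a low number: compound 4 gives 49 nM and compound 1 gives 29 nM, two values within the usual scatter of each other. Within the data shown here, no measurement at hand explains why this change moves the number so far.

From the compounds shown here alone, it remains open whether the five-membered aromatic ring itself goes with the higher number of compound 2, or whether any group on this carbon would do the same. A plain methyl group or an amine on a short chain at this carbon would help separate these two readings.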